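Bromo for Methoxy on a Second Core

The compounds below may be only part of what the source reports. "The series", "measured", "known", "first", "only" and "open" are said of these compounds alone.

Of the compounds shown here, three have been tested in a functional assay on MCF7 cells (Homo sapiens) for antiproliferative activity, read by MTT assay, with a stated time of 72 h; on this read-out higher numbers stand for weaker inhibition and lower numbers for stronger inhibition. Compound 1 `CCOC(=O)c1csc2nc(CN3CCN(C)CC3)c(-c3ccc(OC)cc3)n12` gives 32800 nM in this assay. Compound 2 `CCOC(=O)c1csc2nc(CN3CCN(C)CC3)c(-c3ccc(Br)cc3)n12` gives 68500 nM in this assay. Compound 3 `COc1ccc(-c2cnc3scc(C(=O)NNC(C)=O)n23)cc1` gives 8360 nM in this assay, the lowest of the three numbers, and its gaps to both compound 1 and compound 2 lie beyond the usual scatter.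

Compound 1 and compound 2 share one core and differ in a single place: bromo in place of methoxy on an aromatic carbon. That change brought a 2.1-fold higher number from compound 1 to compound 2 (0.32 log units; beyond the scatter).

Compound 4 `CC(=O)NNC(=O)c1csc2ncc(-c3ccc(Br)cc3)n12` has not yet been measured in this assay. It stands to compound 3 as compound 2 stands to compound 1: bromo in place of methoxy on an aromatic carbon. The place of the change is described in the same words for both pairs, so it is the same change, made here on a second core. How the core of compound 3 differs from the core of compound 1 is not broken down here.

For the measured compounds named here, with only one earlier instance of this change to lean on, the expectation for compound 4 rests on compound 1 and compound 2, where the step was a 2.1-fold higher number from compound 1 to compound 2 (0.32 log units; beyond the scatter). Compound 4 is therefore expected to show a 2.1-fold higher number from compound 3 to compound 4 (0.32 log units; beyond the scatter) in this assay. The estimate for compound 4 is 17500 nM, with a plausible range from 7000 nM to 45000 nM, the width reflecting that a step seen once on a different core may not carry over unchanged.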

Compound 4, half-maximal inhibitory concentration: 1830 nM
For compound 4 the middle estimate is 9.6-fold (0.98 log units) above the measured one; measured number outside the range, below it.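

Replacing methoxy with bromo on the aromatic ring did not act the same way on both cores in this assay: on the core of compound 3, the change gave a 4.6-fold lower number from compound 3 to compound 4 (0.66 log units; beyond the scatter). Set beside the earlier pair, the same swap raised the number on one core and lowered it on the other, so the result from one core cannot simply be carried over to the next: the same change on two cores in this assay, a 2.1-fold higher number (0.32 log units; beyond the scatter) from compound 1 to compound 2 and a 4.6-fold lower number (0.66 log units; beyond the scatter) from compound 3 to compound 4, 9.5-fold (0.98 log units) apart, beyond the scatter of two such steps. For the compounds shown here, with only two pairs, this shows that the core can matter for this change, but it does not show which part of the core decides the direction of the step, or what would happen on a third core.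

The compounds shown leave open whether other groups on the same aromatic carbon, such as chloro, an amine or a plain hydrogen, would also split the two cores in this way or whether the split is particular to bromo and methoxy. Also open, going by these compounds, is whether swapping the side group on the five-membered part of each core for a carboxylic acid would change the size or direction of the bromo step.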